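This account rests on a few compounds, and the source may have more. Where it says the series, first, only, none or still open, it means among the compounds named here.

In an ADME assay on PC-3 cells (Homo sapiens) for cytotoxicity, read by WST assay, tested at 100 uM (on this read-out lower numbers stand for less inhibition and higher numbers for more inhibition at the one concentration tested (going by the name of the read-out)), compound 1 `O=C(Nc1cccc(Oc2ccccc2)c1)C1CCCN(C(=O)c2cc(C(F)(F)F)cc(C(F)(F)F)c2)C1` gives 1%, a reading at the bottom of the scale. Among the compounds with values here, the only other compound measured alongside it, compound 2 `COc1cccc(C(=O)N2CCCC(C(=O)Nc3ccc(Cl)cc3)C2)c1`, gives 0% in this assay, and the gap between the two lies within the scatter, so both compounds stand together at essentially no inhibition, and the two numbers are level.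

Compound 3 `Cc1nc(-c2cccc(NC(=O)C3CCCN(C(=O)c4cc(C(F)(F)F)cc(C(F)(F)F)c4)C3)c2)cs1` has not yet been measured in this assay. It differs from compound 1 in one place: 2-methyl-1,3-thiazol-4-yl in place of phenoxy on an aromatic carbon. Within the data shown here, since both compounds measured so far sit at the floor of the read-out, there is no observed step from which to judge what this change does, and the expectation is that the step of a number 2 percentage points higher from compound 1 to compound 3 (within the scatter) stays within the scatter. Compound 3 is therefore estimated at 3% in this assay, with a likely range from 0% to 15%.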

Compound 3, a percentage reported as inhibition, at one concentration (the size of the read-out at that concentration, not a potency): 1%
Estimate against measurement, compound 3: 2 percentage points above; measured number inside the range.
By their numbers in this assay, from the lowest: compounds 2, 1 and 3 (each within the scatter of the next).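

In this assay, within the data shown here, the swap of phenoxy for 2-methyl-1,3-thiazol-4-yl gives no change at the digits printed from compound 1 to compound 3 (within the scatter), the first step that can be read at this position. It shows that, on this core, replacing a six-membered aromatic ring of carbon only, attached through its oxygen, with a five-membered aromatic ring with 2 hetero atoms does not lift the reading off the bottom of the scale. No measurement here offers an explanation for that flat result.

With every reading so far at the floor, the compounds shown leave open whether anything placed on this aromatic carbon can raise the inhibition at all. An amine or a carboxylic acid in place of phenoxy, for example, might still do so, or might leave the reading just as flat.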